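Chloro to trifluoromethyl on compound 2

A few compounds are considered here, and "the series" means these few. Any claim that something is new, unique, unknown or untested is made for them only; others in the source may bear on it.

In an ADME assay on microsomes from liver (Rattus norvegicus) for metabolic stability, read by LC-MS, using NADPH, with stated times of 6 min and 10 min, tested at 0.5 uM (on this read-out higher numbers stand for a more stable compound and lower numbers for a less stable compound), compound 1 (`CC(=O)N1CCN(c2cc(-c3cc(Cl)c4c(N)ncnn34)ccc2C#N)C(=O)C1(C)C`) gives 89% and compound 2 (`CC(=O)N1C[C@@H](C)N(c2cc(-c3cc(Cl)c4c(N)ncnn34)ccc2C#N)C(=O)C1(C)C`) gives 59%, the lower of the two numbers. That gap, a number 30 percentage points lower from compound 1 to compound 2 (beyond the scatter), came with a methyl in place of hydrogen on a saturated ring carbon. Compound 3 (`CC(=O)N1C[C@@H](C)N(c2cc(-c3cc(C(F)(F)F)c4c(N)ncnn34)ccc2C#N)C(=O)C1(C)C`) differs from compound 2 in another way: trifluoromethyl in place of chloro on an aromatic carbon. For the measured compounds named here, no measured step covers this swap, so the methyl step offers no size to carry over, and no shift beyond the scatter is expected in this assay. The estimated step is a number 1 percentage points higher from compound 2 to compound 3 (within the scatter). For compound 3 the expected value is 60%, with a range of 40% to 80%.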

Compound 3, percent of the compound remaining: 43%
For compound 3 the middle estimate is 17 percentage points above the measured one, and the stated range covers the measured number.
By their numbers in this assay, from the lowest: compound 3; then compound 2; then compound 1.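

In this assay, trifluoromethyl in place of chloro gives a number 16 percentage points lower from compound 2 to compound 3 (beyond the scatter), so this aromatic carbon of the five-membered ring is a second place where a single change moves the number, after the saturated ring carbon of the methyl step. Chloro there is the better of the two groups tested on this read-out. Nothing shown here accounts for the drop. Going by these compounds, whether an amine or a methoxy group at this carbon would do better remains open. So does whether the same swap on compound 1 would give a similar step.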